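The source may report more compounds than this note shows. Statements on the series, on what has been measured and on what is new or still open speak of the compounds shown alone.

Among the three compounds measured so far, compound 1 `NC(=O)c1cnc(N2CCC(Oc3ccccc3C(F)(F)F)CC2)s1` has the lowest number in an assay on microsomes from liver (strain Wistar) for inhibition of acyl-CoA desaturase 1 (Rattus norvegicus), read by HPLC, with stated times of 1 h and 60 min; a higher number here means a weaker inhibitor, a lower number a stronger inhibitor: compound 1 gives 3 nM. Compound 2 `NC(=O)c1csc(N2CCC(Oc3ccccc3C(F)(F)F)CC2)n1` gives 676 nM in this assay, and compound 3 `NC(=O)c1n[nH]c(N2CCC(Oc3ccccc3C(F)(F)F)CC2)n1` gives 127 nM. All three measured steps concern how the five-membered ring that carries the carbamoyl group is built, not the carbamoyl group itself: a 230-fold higher number from compound 1 to compound 2 (2.35 log units; beyond the scatter), a 42-fold higher number from compound 1 to compound 3 (1.63 log units; beyond the scatter), and a 5.3-fold lower number from compound 2 to compound 3 (0.73 log units; beyond the scatter). Compound 4 `NS(=O)(=O)c1cnc(N2CCC(Oc3ccccc3C(F)(F)F)CC2)s1` differs from compound 1 in a different place: sulfamoyl in place of carbamoyl on an aromatic carbon. Going by the values given here, no measured step alters this group, so none bears on the new step directly; what the measured steps do show is that the region around the carbamoyl group tolerates change poorly, as each rearrangement of its ring raised the number by a large margin. Because compound 1 already stands at 3 nM, the expectation is that compound 4 will give a higher number, with a step of a 10-fold higher number from compound 1 to compound 4 (1.00 log units; beyond the scatter), though its size is uncertain. Compound 4 is therefore estimated at 30 nM, with a range from 5 nM to 300 nM.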

Compound 4, half-maximal inhibitory concentration: 41 nM
For compound 4 the middle estimate is 1.4-fold (0.14 log units) below the measured one, within the range that was stated.
By their numbers in this assay, from the lowest: compound 1; then compound 4; then compound 3; then compound 2.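

Going by these compounds alone, compound 1 and compound 4 share the same core, so this is the first measured change to the group on the ring rather than to the ring itself. In this assay, replacing carbamoyl with sulfamoyl gives a 14-fold higher number from compound 1 to compound 4 (1.14 log units; beyond the scatter), a step beyond the scatter that shows this position is sensitive to the identity of the group, yet compound 4 still gives 41 nM, so the larger sulfamoyl group does not abolish inhibition. The two groups have the same count of hydrogen-bond donors, while sulfamoyl has one more heavy atom and one more hydrogen-bond acceptor, but nothing available here explains the higher number for compound 4.

Going by these compounds, with only these two groups at this position, it remains open how a carboxylic acid, a nitrile or an N-methyl carboxamide would compare with carbamoyl on the same ring. On these data alone, it is also open whether sulfamoyl would give a step of similar size on the rings of compound 2 and compound 3, where the carbamoyl group sits in a different ring setting.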